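Swapping the group on the sulfonyl sulfur of compound 2

The source may hold more compounds than are shown below. What is called first, only, known or untested is meant among the compounds shown, and "the series" means these compounds.

Values in a functional assay (Platelet, plasma) for inhibition, with Homo sapiens as the target; on this read-out lower numbers stand for stronger inhibition and higher numbers for weaker inhibition:
- Compound 1 `N#Cc1cc2c(nc1N1CCC(F)(C(=O)NS(=O)(=O)Cc3ccc(Cl)cc3)CC1)COC2=O`: 37200 nM
- Compound 2 `N#Cc1cc2c(nc1N1CCC(F)(C(=O)NS(=O)(=O)c3ccc(Cl)s3)CC1)COC2=O`: 37100 nM

Among the compounds with values here, compound 2 stands level with compound 1, the only other compound measured, as their two values lie within the usual scatter of each other. The next compound, compound 3 `CC(c1ccccc1)S(=O)(=O)NC(=O)C1(F)CCN(c2nc3c(cc2C#N)C(=O)OC3)CC1`, keeps the shared core and changes one group: 1-phenylethyl in place of 5-chlorothiophen-2-yl on a sulfonyl sulfur. In short, 1-phenylethyl takes the place of 5-chlorothiophen-2-yl on a sulfonyl sulfur.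

Within the data shown here, only one measured step bears on this change: a 1.0-fold lower number from compound 1 to compound 2 (0.00 log units; within the scatter). It altered the group at the same place and stayed within the scatter. A single step is thin support, so the range is kept wide. The estimated step is a 1.1-fold lower number from compound 2 to compound 3 (0.03 log units; within the scatter), which means no change beyond the scatter is expected in this assay. For compound 3 the expected value is 35000 nM, with an estimated range from 13000 nM to 90000 nM.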

Compound 3, half-maximal inhibitory concentration: 9950 nM
Compound 3: middle estimate off by 3.5-fold (0.55 log units), on the high side, and the stated range ends above it.
By their numbers in this assay, from the lowest: compound 3; then compounds 2 and 1 (each within the scatter of the next).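

In this assay, the group on the sulfonyl sulfur now proves able to shift the read-out, which the level pair of compound 1 and compound 2 gave no sign of. Putting 1-phenylethyl in place of 5-chlorothiophen-2-yl gives a 3.7-fold lower number from compound 2 to compound 3 (0.57 log units; beyond the scatter), and putting it in place of 4-chlorobenzyl gives a 3.7-fold lower number from compound 1 to compound 3 (0.57 log units; beyond the scatter), so both chlorine-bearing groups stand on the weaker side of the group without chlorine. No measurement here explains this difference.

Compound 3 differs from compound 2 in both its ring and the loss of chlorine, and these single steps cannot separate the two changes. As far as these compounds go, it remains open how a plain benzyl group, a longer chain ending in phenyl, or a chain carrying an amine would read at this sulfonyl sulfur.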